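Chloro in Place of Difluoromethoxy on an Aromatic Carbon

A few compounds are considered here, and "the series" means these few. Any claim that something is new, unique, unknown or untested is made for them only; others in the source may bear on it.

The compounds share a core in which a phenyl-type ring hangs from a small fused bicyclic system. Compound 1 `c1ccc(C2Cc3nccn3C2)cc1` carries no substituent on that ring. In a functional assay on CHO cells for agonist activity at Alpha-1A adrenergic receptor (Homo sapiens), read by FLIPR and calcium flux (on this read-out higher numbers stand for an effect only at larger amounts of compound and lower numbers for an effect already at smaller amounts), compound 1 gives 83 nM; 73 nM; > 10000 nM; 70 nM (4 entries). One of the entries of compound 1 is a limit of the assay rather than a number (the several entries of compound 1 in this assay, 83 nM; 73 nM; > 10000 nM; 70 nM (4 entries)). Compound 2 `FC(F)Oc1ccccc1C1Cc2nccn2C1` adds a difluoromethoxy group to the ring, and in this assay compound 2 gives 11 nM. That is the only number shown for compound 2; one further entry exists without a single number. Compound 3 `Clc1ccccc1C1Cc2nccn2C1` has not yet been measured. It differs from compound 2 by chloro in place of difluoromethoxy on an aromatic carbon. Among the measured compounds shown here, no measured pair shows what such a swap does here, so the expectation rests on compound 2 alone. The change from compound 2 to compound 3 is expected to be a 2.3-fold higher number from compound 2 to compound 3 (0.36 log units; beyond the scatter), a shift that may not exceed the scatter. For compound 3 the estimate in this assay is 25 nM, within the range 8 nM to 80 nM.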

Compound 3, half-maximal effective concentration: 19 nM
The estimate for compound 3 lay 1.3-fold (0.12 log units) above the measured number, within the range that was stated.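

In this assay, the swap gives a 1.7-fold higher number from compound 2 to compound 3 (0.24 log units; within the scatter). Among the compounds shown here, this is the first measured pair for this change, since compound 2 had so far stood alone with a substituent at this place, on an aromatic carbon ortho to a group of 8 heavy atoms, and no step could be read. The pair shows that difluoromethoxy, with its 4 heavy atoms and 1 hydrogen-bond acceptor, can give way to chloro, with 1 heavy atom and no hydrogen-bond acceptor, without a difference that can be told apart from the usual spread of repeated measurements, so in this one pair the oxygen and the two fluorine atoms are not needed to keep the number where it is.

The data shown offer no measured property that would explain why these two groups read alike. From the compounds shown here alone, it remains open whether an amine, a carboxylic acid or a longer chain on this same aromatic carbon would also read alike, and what chloro would do on a different carbon of the ring.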